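Removing the Amino Group from a Chloropurine Cytotoxic

The source may report more compounds than this note shows. Statements on the series, on what has been measured and on what is new or still open speak of the compounds shown alone.

Compound 1 `Nc1nc(Cl)c2ncn(Cc3ccccc3CCl)c2n1` was tested in a functional assay on NCI-H226 cells (Homo sapiens) for cytotoxicity, read by sulforhodamine B assay, with a stated time of 48 h (a lower number here means that less compound is tolerated, a higher number that more compound is tolerated), where compound 1 gives 53700 nM. Among the values shown, compound 1 stands as the only compound with a numerical result; the other measurement is a limit of the assay. Compound 2 `ClCc1ccccc1Cn1cnc2ncnc(Cl)c21` gives > 100000 nM in this assay, which is a limit and not a number. Within the data shown here, the one other value shown thus sits at the limit of > 100000 nM in this assay, at which 1 of the 2 values shown sits.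

Compound 3 `ClCc1ccccc1Cn1cnc2c(Cl)ncnc21` is not yet measured in this assay. It differs from compound 1 in one place: hydrogen in place of amino on an aromatic carbon. Among the measured compounds shown here, no measured pair here shows such a step, so its size can only be expected. The step is expected to be modest, with a higher number more likely than a lower one a 1.3-fold higher number from compound 1 to compound 3 (0.12 log units; within the scatter). Compound 3 is therefore estimated at 70000 nM, with a range from 30000 nM to 150000 nM, and a real chance that only a limit is returned.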

Compound 3, concentration lethal to 50% of the cells: 38900 nM
Estimate against measurement, compound 3: 1.8-fold (0.26 log units) above; the range from low to high includes it.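

Replacing amino with hydrogen on this aromatic carbon, between two ring nitrogen atoms, gives a 1.4-fold lower number from compound 1 to compound 3 (0.14 log units; within the scatter) in this assay. The two compounds therefore cannot be told apart in this assay, and the amino group is not needed here for a numerical result, since the hydrogen compound also gives one. Compound 2 remains a limit and not a number: the limit of > 100000 nM in this assay, at which 1 of the 3 values shown sits.

What the compounds leave open is whether any other group on this carbon, such as a methyl, a methoxy or a dimethylamino group, would move the value beyond the scatter. From the compounds shown here alone, it is also open whether the step would stay this small with a bromo group or a methoxy group in place of the chloro group on the shared core.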